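Swapping hydroxy for fluoro in compound 3

The source may report more compounds than this note shows. Statements on the series, on what has been measured and on what is new or still open speak of the compounds shown alone.

Measured so far in a functional assay on MDA-MB-231 cells (Homo sapiens) for antiproliferative activity, read by sulforhodamine B assay, with a stated time of 48 h; on this read-out higher numbers stand for weaker inhibition and lower numbers for stronger inhibition:
Compound 1 `COc1cc(C(=O)/C=C\Nc2ccc(-c3nc4cc(OC)c(OC)c(OC)c4s3)cc2C)cc([N+](=O)[O-])c1OC` gives 12800 nM
Compound 2 `COc1cc(OC)c2sc(-c3ccc(N/C=C\C(=O)c4ccc(OC)c([N+](=O)[O-])c4)c(C)c3)nc2c1` gives 10800 nM
Compound 3 `COc1ccc2nc(-c3ccc(N/C=C\C(=O)c4ccc(OC)c(O)c4)cc3)sc2c1` gives 18900 nM

Any two of these three values lie within the usual scatter of repeated measurements. So compound 3, with 18900 nM in this set, cannot be told apart from compound 1 or compound 2.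

The next compound to consider is compound 4 `COc1ccc2nc(-c3ccc(N/C=C\C(=O)c4ccc(OC)c(F)c4)cc3)sc2c1`, which has fluoro in place of hydroxy on an aromatic carbon. The change, (fluoro in place of hydroxy on an aromatic carbon), turns 3-hydroxy-4-methoxyphenyl into 3-fluoro-4-methoxyphenyl, and the new group sits ortho to a methoxy group and meta to a large group. The rest of compound 3 stays the same.

For the measured compounds named here, no pair of measured compounds differs in only one place, so the data offer no direct guide to the effect of this swap. The only indication is that the three measured values sit close together even though the structures differ in several places. A change beyond the scatter is therefore not expected, in either direction. The estimate is a 1.3-fold lower number from compound 3 to compound 4 (0.10 log units; within the scatter) in this assay, which would stay within the scatter. The expected value for compound 4 is 15000 nM, with an estimated range from 6000 nM to 40000 nM as the likely span.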

Compound 4, half-maximal inhibitory concentration: 1100 nM
Compound 4: middle estimate off by 14-fold (1.13 log units), on the high side; the whole stated range lies above it.
By their numbers in this assay, from the lowest: compound 4; then compounds 2, 1 and 3 (each within the scatter of the next).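

For the compounds shown here, this is the first pair here that differs in one place only, and it shows that the group on this aromatic carbon can matter a great deal: in this assay, fluoro in place of hydroxy gives a 17-fold lower number from compound 3 to compound 4 (1.24 log units; beyond the scatter). The earlier compounds shown here could not show this, since no two of them differed by a single change and their values all lay within the scatter of one another. Here a swap of just one heavy atom for another, which also takes away the hydrogen-bond donor and acceptor counted for hydroxy, is enough to give a step well beyond that scatter, yet nothing at hand says what lies behind it.

Open, as far as these compounds go, is whether fluoro itself is special or whether the hydroxy group is what holds compound 3 back, which plain hydrogen, chloro, methyl or an amine on the same carbon would help to separate. Also open, from the compounds shown here alone, is whether the same swap gives a similar step on other parts of the series, such as the methyl-bearing compounds with more methoxy groups on the core, like compound 1 and compound 2.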